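Indolyl in place of furanyl: cytotoxicity on Raji cells

The source may hold more compounds than are shown below. What is called first, only, known or untested is meant among the compounds shown, and "the series" means these compounds.

Measured compounds:
- compound 1, `CCOC(=O)CCCCCOc1cccc(CN(C(=O)c2ccc(-c3ccncc3)cc2)C(C)C)c1`; in an ADME assay on Raji cells (Homo sapiens) for cytotoxicity, read by CellTiter-Glo and resazurin assay, with a stated time of 72 h (a higher number here means that more compound is needed for the effect, a lower number that less compound is needed), compound 1 gives > 26000 nM, a limit of the assay
- compound 2, `CCOC(=O)CCCCCOc1cccc(CN(C(=O)c2ccc(-c3cccc(OC(C)C)c3)cc2)C(C)C)c1`; in this assay compound 2 gives > 26000 nM, a limit of the assay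
- compound 3, `CCOC(=O)CCCCCOc1cccc(CN(C(=O)c2ccc(-c3ccco3)cc2)C(C)C)c1`; in this assay compound 3 gives > 26000 nM, a limit of the assay

Compound 3 therefore stands at the limit, and so do the other two values shown (the limit of > 26000 nM in this assay, at which 3 of the 3 values shown sit). The steps between the measured compounds, a step that the two limits leave unreadable from compound 1 to compound 2, a step that the two limits leave unreadable from compound 1 to compound 3 and a step that the two limits leave unreadable from compound 2 to compound 3, are all unreadable for that reason; none of them tells whether the substituent on the aromatic carbon moves the read-out at all.

Compound 4, `CCOC(=O)CCCCCOc1cccc(CN(C(=O)c2ccc(-c3ccc4[nH]ccc4c3)cc2)C(C)C)c1`, is not yet measured. It differs from compound 3 as follows: 1H-indol-5-yl in place of furan-2-yl on an aromatic carbon. Among the compounds with values here, the measured steps bear on this change only in that three different groups at the same place all stayed at the limit, so no step of any size has been seen there. On that basis compound 4 is expected to stay at or near the limit as well, with an expected step that the limit leaves unreadable from compound 3 to compound 4. The estimate for compound 4 in this assay is 30000 nM, within a range from 12000 nM to 80000 nM, with a substantial chance that only a limit is reported again.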

Compound 4, half-maximal effective concentration: > 26000 nM
Compound 4 was reported as a limit (the forecaster's own chance of this, stated with the estimate: 65%); the middle value is on the limit's open side.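

In this assay compound 4 gives > 26000 nM, a limit of the assay. Its steps from compound 1, compound 2 and compound 3 therefore cannot be read: the limit of > 26000 nM in this assay, at which 4 of the 4 values shown sit.

The compounds shown leave open whether any of these four groups on the aromatic carbon moves the read-out at all.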